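The source may hold more compounds than are shown below. What is called first, only, known or untested is meant among the compounds shown, and "the series" means these compounds.

Of the compounds shown here, three on a shared core have been measured so far in a functional assay (Homo sapiens) for inhibition (on this read-out lower numbers stand for stronger inhibition and higher numbers for weaker inhibition), for this series. Compound 1 (`COc1cc(/C=C/C(=O)c2ccccc2F)cc(OC)c1`) comes in at 6000 nM and compound 2 (`COc1cc(/C=C/C(=O)c2cccc(F)c2)cc(OC)c1`) at 9200 nM while compound 3 (`COc1cc(/C=C/C(=O)c2cccc(O)c2)cc(OC)c1`) comes in at 3200 nM on the same read-out. Compound 3 thus stands within the scatter of compound 1 (a 1.9-fold lower number from compound 1 to compound 3 (0.27 log units; within the scatter)) and has a modestly lower number than compound 2 (a 2.9-fold lower number from compound 2 to compound 3 (0.46 log units; beyond the scatter)).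

Compound 4 (`COc1cc(/C=C/C(=O)c2ccc(O)cc2)cc(OC)c1`) has not yet been measured. It carries 4-hydroxyphenyl in place of 3-hydroxyphenyl on a carbonyl carbon. Among the compounds with values here, no measured pair moves a hydroxy group. The closest parallel is the pair that differs only in where the fluorine sits on that ring (a 1.5-fold higher number from compound 1 to compound 2 (0.19 log units; within the scatter)), and this step stays within the scatter. The exchange of fluoro for hydroxy (a 2.9-fold lower number from compound 2 to compound 3 (0.46 log units; beyond the scatter)) is larger, but it changes the group rather than its place, so it says little about this move. With so few compounds the guide is thin, and no step beyond the scatter is expected in this assay for this change. The expected step is small (a 1.3-fold higher number from compound 3 to compound 4 (0.10 log units; within the scatter)) with no firm direction. Compound 4 is expected at 4000 nM (estimated range 1500 nM to 10500 nM).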

Compound 4, half-maximal inhibitory concentration: 14000 nM
Compound 4: the middle estimate sits 3.5-fold (0.54 log units) below what was measured; the measured number lies above the stated range.
By their numbers in this assay, from the lowest: compounds 3, 1, 2 and 4 (each within the scatter of the next, the first and the last beyond it).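

In this assay, the place of the hydroxy group on this ring does matter: 4-hydroxyphenyl in place of 3-hydroxyphenyl on a carbonyl carbon gives a 4.4-fold higher number from compound 3 to compound 4 (0.64 log units; beyond the scatter), a step beyond the scatter, which the fluorine pair, with its step within the scatter, gave no sign of. Hydroxy alone therefore does not secure a low number, since compound 4 stands within the scatter of the fluorine compound 2 (a 1.5-fold higher number from compound 2 to compound 4 (0.18 log units; within the scatter)) and is separated from the other fluorine compound (a 2.3-fold higher number from compound 1 to compound 4 (0.37 log units; beyond the scatter)), so the gain seen with compound 3 belongs to hydroxy at that one place. The data at hand offer no measurement that explains why the two places differ.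

Still open, as far as these compounds go, is how a hydroxy group would fare at the place the fluorine holds in compound 1, and whether fluorine at the place of the hydroxy in compound 4 would give a number like that of compound 4. From the compounds shown here alone, it is also open whether an amine or a methoxy group in place of the hydroxy in compound 3 would keep that compound's number.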